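Notes on the step from compound 3 to compound 4

This account rests on a few compounds, and the source may have more. Where it says the series, first, only, none or still open, it means among the compounds named here.

Measured compounds:
compound 1 `Clc1ccc(C2CC(c3ccc(N4CCCCC4)cc3)=NN2c2nc(-c3ccccc3)cs2)cc1` — 65800 nM
compound 2 `Clc1ccc(C2CC(c3ccc(N4CCCCC4)cc3)=NN2c2nc(-c3ccc(Br)cc3)cs2)cc1` — > 100000 nM
compound 3 `Cc1ccc(-c2csc(N3N=C(c4ccc(N5CCCCC5)cc4)CC3c3ccc(Cl)cc3)n2)cc1` — > 100000 nM

In a functional assay on A-375 cells (Homo sapiens) for antiproliferative activity, read by MTT assay, with a stated time of 72 h (a higher number here means a weaker inhibitor, a lower number a stronger inhibitor), compound 1 gives 65800 nM. For compound 2 the assay returns only a limit, > 100000 nM. For compound 3 the assay likewise returns only a limit, > 100000 nM, so compound 3 stands at the edge of what the assay reports and not on a number. The steps of an at least 1.5-fold higher number from compound 1 to compound 2 (0.18 log units; that floor lies within the scatter) and an at least 1.5-fold higher number from compound 1 to compound 3 (0.18 log units; that floor lies within the scatter) are read as floors only, and a step that the two limits leave unreadable from compound 2 to compound 3 cannot be read, which follows from the limit of > 100000 nM in this assay, at which 2 of the 3 values shown sit.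

Compound 4 `CS(=O)(=O)c1ccc(-c2csc(N3N=C(c4ccc(N5CCCCC5)cc4)CC3c3ccc(Cl)cc3)n2)cc1` differs from compound 3 by methylsulfonyl in place of methyl on an aromatic carbon. Going by the values given here, no measured step involves a methylsulfonyl, and the two steps that leave compound 1 give no direction beyond a floor, so the change carries no readable precedent here. Compound 4 is expected to return a limit again or a number near it, estimated at 120000 nM with a range from 40000 nM to 350000 nM. The expected step that the limit leaves unreadable from compound 3 to compound 4 is accordingly estimated as none beyond the scatter.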

Compound 4, half-maximal inhibitory concentration: > 100000 nM
Compound 4 gave a limit, no number; the forecaster's own chance of this, stated with the estimate: 65%; the middle value does not contradict the limit.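

In this assay compound 4 returns only a limit, > 100000 nM. With methylsulfonyl on this aromatic carbon, para to a large group, the series therefore adds a group carrying hydrogen-bond acceptors to bromo and methyl, and compound 4 again gives no number, so the limit does not depend on that one kind of replacement among the three compounds. The only readable comparison is a floor, an at least 1.5-fold higher number from compound 1 to compound 4 (0.18 log units; that floor lies within the scatter), and the steps between compound 2, compound 3 and compound 4 cannot be read, because each of these compounds stands at the same edge of the assay: the limit of > 100000 nM in this assay, at which 3 of the 4 values shown sit.

Going by these compounds, it remains open whether compound 2, compound 3 or compound 4 differs from compound 1 beyond the scatter, and how these three compounds rank among themselves. On these data alone, it also remains open whether an amine, a carboxylic acid or a methoxy group in the same place would bring a compound back to a number in this assay.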